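Cyano in Place of Hydrogen on a Pyrazine Hydrazone

The compounds below may be only part of what the source reports. "The series", "measured", "known", "first", "only" and "open" are said of these compounds alone.

Compound 1 `O=C(N/N=C/c1ccccc1)c1cnccn1` is the reference point of this small set. In an ADME assay on J774 cells (Mus musculus) for cytotoxicity, read by MTT assay, with a stated time of 48 h, tested at 50 ug/mL (a higher number here means a weaker effect of the compound at the concentration tested, a lower number a stronger effect), compound 1 gives 100%, and it stands level with compound 2 `O=C(N/N=C/c1cccc(Br)c1)c1cnccn1`, which gives 100% in this assay; together they hold the highest of the three numbers measured. Compound 3 `CCOc1cccc(/C=N/NC(=O)c2cnccn2)c1` gives 74% in this assay, the furthest of the three from compound 1.

Going by the values given here, two measured steps bear on the change now in question. The step of no change at the digits printed from compound 1 to compound 2 (within the scatter) shows that a small halogen entering on an aromatic carbon left the number where it was. The step of a number 26 percentage points lower from compound 1 to compound 3 (beyond the scatter) shows that a larger ethoxy group entering at the same kind of place lowered the number modestly, and a number 26 percentage points lower from compound 2 to compound 3 (beyond the scatter) repeats that picture from the other direction.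

Compound 4 `N#Cc1ccc(/C=N/NC(=O)c2cnccn2)cc1` differs from compound 1 in one way: cyano in place of hydrogen on an aromatic carbon. The entering group is small, with two heavy atoms and no ring, placed on an aromatic carbon of the six-membered carbon ring, para to a large group.

Since the small bromo in compound 2 gave no change at the digits printed from compound 1 to compound 2 (within the scatter), the expected step for compound 4 is a number 4 percentage points lower from compound 1 to compound 4 (within the scatter), that is, none beyond the scatter. Compound 4 is therefore estimated at 96% in this assay, within a range from 78% to 105%.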

Compound 4, a percentage reported as activity, at one concentration (the size of the read-out at that concentration, not a potency): 100%
Compound 4: middle estimate off by 4 percentage points, on the low side; the range from low to high includes it.
By their numbers in this assay, from the lowest: compound 3; then compounds 1, 2 and 4 (each within the scatter of the next).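

In this assay, cyano in place of hydrogen on an aromatic carbon, para to a large group, gives no change at the digits printed from compound 1 to compound 4 (within the scatter). Going by these compounds alone, this adds a second case to the bromo step: a group with a triple bond and a nitrogen atom, unlike anything on the earlier compounds, can sit at this place on the carbon ring with no shift in the read-out beyond the usual scatter, so this position accepts this change at the single concentration tested. No measurement here explains why the number stays put, so the result stands as an observation and nothing more.

The compounds shown leave open what other kinds of group would do at this same place, such as an amine, a carboxylic acid or a longer chain, and whether any of them would lower the number as the ethoxy group of compound 3 does. Since the read-out is the size of the effect at one concentration and not a potency, it also leaves open whether compound 1 and compound 4 would still match at other concentrations.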